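A few compounds are considered here, and "the series" means these few. Any claim that something is new, unique, unknown or untested is made for them only; others in the source may bear on it.

Measured so far:
compound 1, `Nc1scc(CN2CCN(c3ccc([N+](=O)[O-])cc3)CC2)c1C(=O)c1ccc(Cl)cc1`: -12%
compound 2, `Nc1scc(CN2CCN(c3ccncc3)CC2)c1C(=O)c1ccc(Cl)cc1`: -4%

In a functional assay on CHO cells with adenosine receptor A1 (Homo sapiens) as the target, read by cAMP accumulation and immunoassay, with a stated time of 6 min, tested at 0.01 uM (on this read-out lower numbers stand for a stronger effect and higher numbers for a weaker effect at the one concentration tested), compound 2 holds the higher of the two numbers, and its nearest neighbour is compound 1, whose number is lower by a number 8 percentage points higher from compound 1 to compound 2 (within the scatter). That step, the only one measured, swapped one aryl group on the ring nitrogen for another and left no change beyond the scatter. Compound 3, `Nc1scc(CN2CCN(c3ccc(F)c(Cl)c3)CC2)c1C(=O)c1ccc(Cl)cc1`, differs from compound 2 in the same place: 3-chloro-4-fluorophenyl in place of pyridin-4-yl on an amine nitrogen in a ring. Going by the values given here, since the one aryl swap recorded, a number 8 percentage points higher from compound 1 to compound 2 (within the scatter), stayed within the scatter, no step beyond it is expected for compound 3 in this assay, and its estimated value is -7%, spanning -20% to 8%, a step of a number 3 percentage points lower from compound 2 to compound 3 (within the scatter).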

Compound 3, a percentage reported as activity, at one concentration (the size of the read-out at that concentration, not a potency): 4.2%
For compound 3 the middle estimate is 11.2 percentage points below the measured one; measured number inside the range.
By their numbers in this assay, from the lowest: compounds 1, 2 and 3 (each within the scatter of the next, the first and the last beyond it).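

In this assay a change of aryl group on the amine nitrogen in the ring now gives a step that stands clear of the scatter: a number 16.2 percentage points higher from compound 1 to compound 3 (beyond the scatter) with 3-chloro-4-fluorophenyl in place of 4-nitrophenyl. The change from pyridin-4-yl does not stand clear, being a number 8.2 percentage points higher from compound 2 to compound 3 (within the scatter) and leaving compound 2 within the scatter of both other compounds. Nothing available accounts for either step.

As far as these compounds go, whether a benzyl group or a phenyl ring bearing an amine or a carboxylic acid would move the number further remains open. So does whether the modest step would hold at other concentrations.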